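Methyl on the ring nitrogen: compound 2 to compound 3

The compounds below may be only part of what the source reports. "The series", "measured", "known", "first", "only" and "open" are said of these compounds alone.

Measured so far:
compound 1 `CN(c1ccc(Oc2ncnc3sccc23)cc1)c1nccc(N2CCCC2)n1` — 31%
compound 2 `c1ccc2c(c1)CCN(c1ccnc(Nc3ccc(Oc4ncnc5sccc45)cc3)n1)C2` — 26.8%

In a functional assay on MDA-MB-231 cells (Homo sapiens) for inhibition, read by MTT assay, with a stated time of 72 h, tested at 20 uM (a higher number here means more inhibition at the concentration tested (going by the name of the read-out), a lower number less inhibition), compound 1 gives 31% and compound 2 gives 26.8%. Compound 2 has the lower of the two numbers, but the gap to compound 1 falls within the usual scatter, so the two values are best read as alike; neither compound can be said to have the higher number in this assay.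

The unmeasured compound 3 `CN(c1ccc(Oc2ncnc3sccc23)cc1)c1nccc(N2CCc3ccccc3C2)n1` differs from compound 2 in one place: methyl in place of hydrogen on a nitrogen on an aromatic ring. Going by the values given here, no pair of measured compounds with exactly this change has been seen, so the effect of the methyl is unknown here. Compound 1 also carries a methyl on the nitrogen on an aromatic ring, and its value sits next to that of compound 2. For this reason a step from compound 2 to compound 3 in this assay is expected to be small, with no clear direction, and likely within the scatter. The estimate for compound 3 in this assay is 30%, in a range from 15% to 45%, which means an expected step of a number 3.2 percentage points higher from compound 2 to compound 3 (within the scatter).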

Compound 3, a percentage reported as inhibition, at one concentration (the size of the read-out at that concentration, not a potency): 24.3%
Compound 3: middle estimate off by 5.7 percentage points, on the high side, within the range that was stated.
By their numbers in this assay, from the lowest: compounds 3, 2 and 1 (each within the scatter of the next).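

In this assay the methyl can now be read on its own, since this pair differs only at that spot: methyl in place of hydrogen on a nitrogen on an aromatic ring gives a number 2.5 percentage points lower from compound 2 to compound 3 (within the scatter) and so leaves this pair of compounds indistinguishable. With the methyl kept, 1,2,3,4-tetrahydroisoquinolin-2-yl in place of pyrrolidin-1-yl on an aromatic carbon gives a number 6.7 percentage points lower from compound 1 to compound 3 (within the scatter) and can likewise not be told from the scatter. Nothing at hand bears on why these numbers fall where they do.

Going by these compounds, whether an ethyl group or a longer chain on that nitrogen would move the number beyond the scatter stays open. So does the outcome of a morpholin-4-yl or piperazin-1-yl group in place of the 1,2,3,4-tetrahydroisoquinolin-2-yl.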